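Swapping the aryl group on the chain: compound 3 to compound 4

The source may report more compounds than this note shows. Statements on the series, on what has been measured and on what is new or still open speak of the compounds shown alone.

Measured compounds:
Compound 1 `O[C@@H](c1ccccc1)[C@H]1CO[C@H](c2ccccc2)[C@@H](C/C=C/c2cccc(F)c2)C1` gives 8380 nM in a functional assay on HeLa cells (Homo sapiens) for cytotoxicity, read by WST assay, with a stated time of 48 h; on this read-out lower numbers stand for stronger inhibition and higher numbers for weaker inhibition.
Compound 2 `O[C@@H](c1ccccc1)[C@H]1CO[C@H](c2ccccc2)[C@@H](C/C=C/c2cccnc2)C1` is reported in this assay only as a limit, > 100000 nM, not as a number (the limit of > 100000 nM in this assay, at which 1 of the 3 values shown sits).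
Compound 3 `O=[N+]([O-])c1ccc(/C=C/C[C@H]2C[C@@H]([C@@H](O)c3ccccc3)CO[C@@H]2c2ccccc2)cc1` gives 12400 nM in this assay.

Among the two numbers, compound 3 stands highest, nearest to compound 1: a 1.5-fold higher number from compound 1 to compound 3 (0.17 log units; within the scatter). The change to compound 2 was large: an at least 11-fold higher number from compound 1 to compound 2 (1.07 log units; beyond the scatter); and an at least 8.0-fold lower number from compound 2 to compound 3 (0.90 log units; beyond the scatter).

Compound 4 `Oc1ccccc1/C=C/C[C@H]1C[C@@H]([C@@H](O)c2ccccc2)CO[C@@H]1c1ccccc1` differs from compound 3 by one change: 2-hydroxyphenyl in place of 4-nitrophenyl on a double-bonded chain carbon bound to a double-bonded chain carbon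

One aryl replacement left the number almost unchanged, another moved it far, so the direction is uncertain; a modest step is expected, a 1.2-fold higher number from compound 3 to compound 4 (0.08 log units; within the scatter). Compound 4 is estimated at 15000 nM, between 4000 nM and 60000 nM.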

Compound 4, half-maximal inhibitory concentration: 21800 nM
Compound 4: the middle estimate sits 1.5-fold (0.16 log units) below what was measured, within the range that was stated.
By their numbers in this assay, from the lowest: compounds 1, 3 and 4 (each within the scatter of the next, the first and the last beyond it). At a limit, above all of these: compound 2.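

Replacing 4-nitrophenyl with 2-hydroxyphenyl gives a 1.8-fold higher number from compound 3 to compound 4 (0.25 log units; within the scatter), so these two groups cannot be told apart here. Against 3-fluorophenyl, however, 2-hydroxyphenyl gives a 2.6-fold higher number from compound 1 to compound 4 (0.42 log units; beyond the scatter), the first step beyond the scatter among the aryl groups at this place with a ring of carbon only. The pyridin-3-yl of compound 2 stays apart, with an at least 4.5-fold lower number from compound 2 to compound 4 (0.66 log units; beyond the scatter), though that step rests on a limit: the limit of > 100000 nM in this assay, at which 1 of the 4 values shown sits.

Still open is whether the hydroxy group itself matters, since plain phenyl at this place is not among the compounds shown. So is what an amine or a carboxylic acid on this ring, or a longer chain, would do.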